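The source may report more compounds than this note shows. Statements on the series, on what has been measured and on what is new or still open speak of the compounds shown alone.

Measured compounds in a functional assay on LOX IMVI cells (Homo sapiens) for inhibition, read by sulforhodamine B assay, with a stated time of 48 h; on this read-out lower numbers stand for stronger inhibition of growth and higher numbers for weaker inhibition of growth:
- compound 1, `CN1CCN(CCCOc2cccc3nc(Nc4ccc(Cl)c(F)c4)ccc23)CC1`: 1640 nM
- compound 2, `CN1CCN(CCCOc2cccc3nc(Nc4ccc(F)c(F)c4)ccc23)CC1`: 1030 nM

Among the compounds with values here, compound 2 sits at one end of the two numbers, but its only neighbour is compound 1, and the step of a 1.6-fold lower number from compound 1 to compound 2 (0.20 log units; within the scatter) lies within the scatter, so the two compounds cannot be told apart on this read-out.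

Compound 3, `CN1CCN(CCCOc2cccc3nc(Nc4cccc(Cl)c4)ccc23)CC1`, is not yet measured. It differs from compound 2 in one place: 3-chlorophenyl in place of 3,4-difluorophenyl on a nitrogen on an aromatic ring. Two things change at once, a halogen exchange and the loss of one fluorine. Only the halogen exchange has a measured counterpart: the step from compound 1 to compound 2, a 1.6-fold lower number from compound 1 to compound 2 (0.20 log units; within the scatter), which shows chloro and fluoro on this ring as interchangeable within the scatter. Within the data shown here, the loss of one fluorine has no measured counterpart, so nothing indicates a shift in either direction.

The step from compound 2 to compound 3 in this assay is therefore expected to be a 1.4-fold higher number from compound 2 to compound 3 (0.13 log units; within the scatter), nothing beyond the scatter. Compound 3 is expected to give 1400 nM, within a range of 500 nM to 4000 nM.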

Compound 3, concentration for 50% growth inhibition: 1680 nM
Compound 3: the middle estimate sits 1.2-fold (0.08 log units) below what was measured; low and high end bracket the measured number.
By their numbers in this assay, from the lowest: compounds 2, 1 and 3 (each within the scatter of the next).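

In this assay, within the data shown here, the earlier pair compared only two dihalogenated rings. The series now includes a ring with a single halogen: 3-chlorophenyl in place of 3,4-difluorophenyl gives a 1.6-fold higher number from compound 2 to compound 3 (0.21 log units; within the scatter), and 3-chlorophenyl in place of 4-chloro-3-fluorophenyl gives a 1.0-fold higher number from compound 1 to compound 3 (0.01 log units; within the scatter). On the core shared by these compounds, the three halogenated aryl groups on this nitrogen therefore cannot be told apart on this read-out, whether the ring carries one halogen or two, and the second halogen shows no effect beyond the scatter in these pairs. No measurement at hand explains this result.

As far as these compounds go, because all three groups are halogenated phenyl rings, it remains open whether unsubstituted phenyl, 3-methoxyphenyl or a pyridine ring on this nitrogen would stay within the same narrow band in this assay. Also open, from the compounds shown here alone, is whether the flat response holds when the 4-methylpiperazine or the propyl chain is changed, for instance to a morpholine or a longer chain.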